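Removing a Methyl From the Saturated Ring

The source may hold more compounds than are shown below. What is called first, only, known or untested is meant among the compounds shown, and "the series" means these compounds.

Compound 1 `C[C@@H]1Cc2cc(C(N)=O)cnc2N1` is the reference; in an ADME assay on the whole organism (Mus musculus, strain C57BL6/N) for pharmacokinetics, read by LC-MS, with a stated time of 24 h, at a dose of 1 mg/kg by the intravenous route (on this read-out lower numbers stand for slow clearance and higher numbers for fast clearance), compound 1 gives 36.1 mL/min/kg. Compound 2 `NC(=O)c1cnc2c(c1)CCN2` differs by hydrogen in place of methyl on a saturated ring carbon, and in this assay compound 2 gives 64.2 mL/min/kg, a step of a 1.8-fold higher number from compound 1 to compound 2 (0.25 log units; within the scatter). Compound 3 `Cc1c(C(N)=O)cnc2c1C[C@@H](C)N2` differs from compound 1 by methyl in place of hydrogen on an aromatic carbon, and in this assay compound 3 gives 90 mL/min/kg, a step of a 2.5-fold higher number from compound 1 to compound 3 (0.40 log units; beyond the scatter). Compound 4 `Cc1c(C(N)=O)cnc2c1CCN2`, still unmeasured in this assay, differs from compound 3 by hydrogen in place of methyl on a saturated ring carbon, the same change as that from compound 1 to compound 2. Compound 4 is expected to show a step of a 1.4-fold higher number from compound 3 to compound 4 (0.16 log units; within the scatter), of a size similar to the earlier one, because a 1.8-fold higher number from compound 1 to compound 2 (0.25 log units; within the scatter) was seen for the same change. Compound 4 is therefore estimated at 130 mL/min/kg, between 70 mL/min/kg and 230 mL/min/kg.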

Compound 4, clearance: 182 mL/min/kg
Estimate against measurement, compound 4: 1.4-fold (0.15 log units) below; measured number inside the range.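

Replacing the methyl on the saturated ring carbon with hydrogen gives, in this assay, a 2.0-fold higher number from compound 3 to compound 4 (0.31 log units; beyond the scatter), and this step agrees with the one seen for the same change on the other core: the same change on two cores in this assay, a 1.8-fold higher number (0.25 log units; within the scatter) from compound 1 to compound 2 and a 2.0-fold higher number (0.31 log units; beyond the scatter) from compound 3 to compound 4, 1.1-fold (0.06 log units) apart, within the scatter of two such steps. Placing a methyl on the aromatic carbon gives a 2.8-fold higher number from compound 2 to compound 4 (0.45 log units; beyond the scatter), which also agrees with its earlier counterpart: the same change on two cores in this assay, a 2.5-fold higher number (0.40 log units; beyond the scatter) from compound 1 to compound 3 and a 2.8-fold higher number (0.45 log units; beyond the scatter) from compound 2 to compound 4, 1.1-fold (0.06 log units) apart, within the scatter of two such steps. Each change therefore carried over between these two cores at a similar size, but the four compounds do not show why clearance shifts or whether the same would hold on any other core.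

The compounds shown leave open how a larger or different group, such as an ethyl, a methoxy or an amine, would behave at either place.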